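Swapping the Pyrrolidine Cap Before the Number Is Known

This account rests on a few compounds, and the source may have more. Where it says the series, first, only, none or still open, it means among the compounds named here.

Three measured compounds share one core. Compound 1 `CN1CCN(c2ccc(Nc3ncc4nc(Nc5ccccc5)n([C@H]5CCNC5)c4n3)cc2)CC1` carries a bare pyrrolidin-3-yl on an aromatic nitrogen, and in a functional assay on HCC827 cells (Homo sapiens) for antiproliferative activity, read by MTT assay, with a stated time of 72 h (a higher number here means a weaker inhibitor, a lower number a stronger inhibitor), compound 1 gives 530 nM. Compound 2 `CN1CCN(c2ccc(Nc3ncc4nc(Nc5ccccc5)n([C@@H]5CCN(C(=O)OC(C)(C)C)C5)c4n3)cc2)CC1` carries 1-(tert-butoxycarbonyl)pyrrolidin-3-yl instead; in this assay compound 2 gives 12 nM, which is a 44-fold lower number from compound 1 to compound 2 (1.65 log units; beyond the scatter). Compound 3 `CN1CCN(c2ccc(Nc3ncc4nc(Nc5ccc(F)cc5)n([C@@H]5CCN(C(=O)OC(C)(C)C)C5)c4n3)cc2)CC1` keeps that group and has fluoro in place of hydrogen on an aromatic carbon; in this assay compound 3 gives 27 nM, the second highest of the three numbers, and the fluoro step was a 2.3-fold higher number from compound 2 to compound 3 (0.35 log units; beyond the scatter).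

Compound 4 `CCOC(=O)CN1CC[C@H](n2c(Nc3ccc(F)cc3)nc3cnc(Nc4ccc(N5CCN(C)CC5)cc4)nc32)C1` differs from compound 3 in one place: 1-((ethoxycarbonyl)methyl)pyrrolidin-3-yl in place of 1-(tert-butoxycarbonyl)pyrrolidin-3-yl on an aromatic nitrogen. The step from compound 1 to compound 2 shows that what sits on the pyrrolidin-3-yl group can move the number a great deal; the fluoro step does not bear here, since the fluoro stays. Among the compounds with values here, no measured step swaps one such substituent for another, so its direction is not settled by the data. Because compound 4 keeps a substituent rather than returning to the bare pyrrolidin-3-yl of compound 1 with 530 nM, a modest rise is expected, that is a 2.2-fold higher number from compound 3 to compound 4 (0.35 log units; beyond the scatter). Compound 4 is estimated at 60 nM, within 15 nM to 250 nM.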

Compound 4, half-maximal inhibitory concentration: 1810 nM
Compound 4: middle estimate off by 30-fold (1.48 log units), on the low side; the measured number lies above the stated range.
By their numbers in this assay, from the lowest: compound 2; then compound 3; then compound 1; then compound 4.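

In this assay, replacing 1-(tert-butoxycarbonyl)pyrrolidin-3-yl with 1-((ethoxycarbonyl)methyl)pyrrolidin-3-yl gives a 67-fold higher number from compound 3 to compound 4 (1.83 log units; beyond the scatter), so at this position a substituent on the pyrrolidine does not by itself keep the number low, and which substituent it is matters greatly. The change looks small when counted: the two groups are close in heavy atoms, the ring and the defined stereocentre stay, and hydrogen-bond acceptors go from 2 to 3, yet the step is large, so similar counts are no guide to the outcome here. Nothing measured among these compounds explains why this swap moves the number so far.

The swap changes the whole group at once, so the compounds shown cannot tell whether the ethyl ester, the methylene link to the ring nitrogen or the loss of the tert-butyl group accounts for the step. Also open, on these data alone, is where a carboxylic acid in place of the ethyl ester, an amide, or a plain methyl on the ring nitrogen would fall, and whether the same swap would have a similar effect without the fluoro.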